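Removing a methoxy group in a cytotoxicity series

The compounds below may be only part of what the source reports. "The series", "measured", "known", "first", "only" and "open" are said of these compounds alone.

Measured compounds:
Compound 1 `COc1cc(-c2cc(/C=C/C(=O)c3ccc(N)cc3)[nH]n2)cc(OC)c1OC` gives -32% in a functional assay on NCI-H460 cells (Homo sapiens) for cytotoxicity, read by sulforhodamine B assay, with a stated time of 48 h, tested at 10 uM; on this read-out lower numbers stand for a stronger effect and higher numbers for a weaker effect at the one concentration tested.
Compound 2 `COc1ccc(-c2cc(/C=C/C(=O)c3ccc(N)cc3)[nH]n2)cc1OC` gives -49% in this assay.
Compound 3 `COc1cc(C(=O)/C=C/c2cc(-c3cc(OC)c(OC)c(OC)c3)n[nH]2)cc(OC)c1OC` gives -51% in this assay.

Compounds 1 and 2 share a core and differ in one place: hydrogen in place of methoxy on an aromatic carbon. This change made a step of a number 17 percentage points lower from compound 1 to compound 2 (beyond the scatter), so the smaller compound showed the stronger effect on the cells. Compound 3 is built on a different arrangement of the same pieces; how its core differs from that of compound 1 is not broken down here, and its value sits close to that of compound 2, with the two lying within the scatter of each other.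

Compound 4 `COc1ccc(-c2cc(/C=C/C(=O)c3cc(OC)c(OC)c(OC)c3)[nH]n2)cc1OC` has not yet been measured in this assay. It is related to compound 3 by exactly the change that relates compound 2 to compound 1: hydrogen in place of methoxy on an aromatic carbon. The surroundings of the changed position are described in the same words for both pairs, so the two changes are the same kind of change made on two different cores.

Going by the values given here, with only a single earlier example to go by, the expectation is a step of about a number 11 percentage points lower from compound 3 to compound 4 (beyond the scatter) from compound 3 to compound 4, a little more cautious than the step seen from compound 1 to compound 2, because the earlier step of a number 17 percentage points lower from compound 1 to compound 2 (beyond the scatter) was observed on another core and a single pair cannot show how far it carries over. On that basis compound 4 is estimated to give -62% in this assay, most likely between -80% and -42%.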

Compound 4, a percentage reported as activity, at one concentration (the size of the read-out at that concentration, not a potency): -41%
Compound 4: the middle estimate sits 21 percentage points below what was measured; the whole stated range lies below it.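

In this assay, going by these compounds alone, replacing a methoxy group with hydrogen gave a number 10 percentage points higher from compound 3 to compound 4 (within the scatter) and so produced no step that can be told apart from the usual variation between repeated measurements. The same change therefore did not give the same result on the two cores, and the gap between its two steps is larger than chance scatter would readily explain: the same change on two cores in this assay, a number 17 percentage points lower (beyond the scatter) from compound 1 to compound 2 and a number 10 percentage points higher (within the scatter) from compound 3 to compound 4, 27 percentage points apart, beyond the scatter of two such steps. Within the data shown here, this does not show why the cores respond differently or whether either result is typical, as the comparison rests on only two pairs, each read at a single concentration, and a third core might resemble either pair or neither.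

The compounds shown leave open which of the structural differences between the two cores separates these outcomes, and a further matched pair on each core would help to settle how reliable each step is. Also open, from the compounds shown here alone, is how a hydroxyl group, a fluorine atom or a longer chain such as ethoxy at this position would compare with methoxy and hydrogen on either core.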